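From a Methyl Group to a Fluorophenyl Chain

The source may hold more compounds than are shown below. What is called first, only, known or untested is meant among the compounds shown, and "the series" means these compounds.

Measured compounds:
compound 1 `CN1CCc2c(ccc(CN3CCCCCC3)c2O)C1` — > 100000 nM
compound 2 `Oc1c(CN2CCCCCC2)ccc2c1CCN(CCCC(c1ccccc1)c1ccccc1)C2` — 460 nM
compound 3 `Oc1c(CN2CCCCCC2)ccc2c1CCN(CCCCCC(c1ccccc1)c1ccccc1)C2` — 1100 nM

All three were tested in an assay on IMR-32 cells for inhibition of Voltage-dependent N-type calcium channel subunit alpha-1B (Homo sapiens); on this read-out lower numbers stand for stronger inhibition and higher numbers for weaker inhibition. Among the compounds with values here, compound 1 returns only a limit, > 100000 nM, not a number, and it is the single compound that sits there (the limit of > 100000 nM in this assay, at which 1 of the 3 values shown sits). Compound 2 gives 460 nM in this assay, and compound 3 gives 1100 nM. Both carry a long chain on the ring amine of the shared core, whereas compound 1 carries only a methyl group there.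

Compound 4 `Oc1c(CN2CCCCCC2)ccc2c1CCN(CCCCc1ccc(F)cc1)C2` has not yet been measured. It differs from compound 1 by 3-(4-fluorophenyl)propyl in place of hydrogen on a saturated chain carbon bound to an amine nitrogen in a ring. This change again places a longer substituent on the ring amine, though with a single aromatic ring rather than the two found in compound 2 and compound 3. The account expects a large step downward in this assay, an at least 40-fold lower number from compound 1 to compound 4 (1.60 log units; beyond the scatter), because compound 2 at 460 nM and compound 3 at 1100 nM both reach measurable inhibition with extended amine chains. Compound 4 is estimated at 2500 nM, with a range from 500 nM to 12000 nM.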

Compound 4, half-maximal inhibitory concentration: 5100 nM
Compound 4: middle estimate off by 2.0-fold (0.31 log units), on the low side; the measured number falls inside the stated range.
By their numbers in this assay, from the lowest: compound 2; then compound 3; then compound 4. At a limit, above all of these: compound 1.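

The 3-(4-fluorophenyl)propyl group in place of hydrogen gives an at least 19-fold lower number from compound 1 to compound 4 (1.29 log units; beyond the scatter), so at this position a chain with one aromatic ring also brings a measurable number, not only the chains with two aromatic rings in compound 2 and compound 3. In this assay compound 4 gives 5100 nM, while compound 3 gives 1100 nM and compound 2 gives 460 nM. Compound 1 is the only compound held at a limit of the assay, so the step has a floor and no known full size: the limit of > 100000 nM in this assay, at which 1 of the 4 values shown sits.

Compound 4 differs from compound 2 in both the fluorine and the second aromatic ring, so the compounds shown do not separate these two features. They also leave open how a chain ending in an unsubstituted phenyl, a pyridine or a carboxylic acid would read in this assay.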